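A few compounds are considered here, and "the series" means these few. Any claim that something is new, unique, unknown or untested is made for them only; others in the source may bear on it.

Measured in a functional assay on CCRF-CEM cells (Homo sapiens); a higher number here means a weaker inhibitor, a lower number a stronger inhibitor:
Compound 1 `CCCCCCc1cn([C@@H]2O[C@H](CO)[C@@H](O)[C@H]2O)nn1`: > 200000 nM, a limit of the assay
Compound 2 `CCCCCCCCc1cn([C@@H]2O[C@H](CO)[C@@H](O)[C@H]2O)nn1`: 44000 nM
Compound 3 `OCc1cn([C@@H]2O[C@H](CO)[C@@H](O)[C@H]2O)nn1`: > 200000 nM, a limit of the assay

Compound 3 gives no number, only a limit, and it stands at the limit of > 200000 nM in this assay, at which 2 of the 3 values shown sit. Compound 4 `OC[C@H]1O[C@@H](n2cc(-c3ccc(F)cc3)nn2)[C@H](O)[C@@H]1O` has not yet been measured. It departs from compound 3 as follows: 4-fluorophenyl in place of hydroxymethyl on an aromatic carbon. In words, 4-fluorophenyl takes the place of hydroxymethyl on an aromatic carbon.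

Going by the values given here, three measured steps bear on this change, all of them at the same place on the shared core. The first is an at least 4.5-fold lower number from compound 1 to compound 2 (0.65 log units; beyond the scatter). The second is an at least 4.5-fold higher number from compound 2 to compound 3 (0.65 log units; beyond the scatter). The third is a step that the two limits leave unreadable from compound 1 to compound 3. Only compound 2 reaches a number in this assay, and it carries a long saturated chain, whereas the group entering compound 4 is an aromatic ring. Among the compounds with values here, no measured step tests such a ring, so these steps are only a loose guide.

A modest move to a lower number is expected, and the result may well remain at the limit. Compound 2, at 44000 nM, marks the strongest effect expected from this kind of change. The expected change is an at least 1.6-fold lower number from compound 3 to compound 4 (0.22 log units; that floor lies within the scatter). For compound 4 the estimate is 120000 nM, with an expected range from 40000 nM to 350000 nM.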

Compound 4, half-maximal inhibitory concentration: 217000 nM
Estimate against measurement, compound 4: 1.8-fold (0.26 log units) below; the range from low to high includes it.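

In this assay compound 4 gives 217000 nM. Neither the step from compound 3 to compound 4 nor the step from compound 1 to compound 4 can be read. Compound 1 and compound 3 each have only a limit. The compounds shown leave open how far 4-fluorophenyl, in place of hydroxymethyl, actually moves the number.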